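Methoxy for chloro in a cytotoxicity series

A few compounds are considered here, and "the series" means these few. Any claim that something is new, unique, unknown or untested is made for them only; others in the source may bear on it.

Compound 1 `CNC(=O)c1cc(Oc2ccc(NC(=O)c3cc(-c4ccc(Cl)cc4)ncn3)cc2)ccn1` is the reference of this set. In a functional assay on MCF7 cells (Homo sapiens) for cytotoxicity, read by MTT assay, with a stated time of 72 h (on this read-out lower numbers stand for stronger inhibition and higher numbers for weaker inhibition), compound 1 gives only a limit, > 100000 nM. Compound 2 `CNC(=O)c1cc(Oc2ccc(NC(=O)c3nccc(-c4cccc(Cl)c4)n3)cc2)ccn1` likewise gives only a limit, > 100000 nM. Compound 3 `CNC(=O)c1cc(Oc2ccc(NC(=O)c3cc(-c4ccc(Cl)cc4)ncn3)cc2F)ccn1` also gives only a limit, > 100000 nM. Among the measured compounds shown here, the single step between compounds that differ in one place, a step that the two limits leave unreadable from compound 1 to compound 3, cannot be read because both values sit at the limit of > 100000 nM in this assay, at which 3 of the 3 values shown sit. Compound 4 `CNC(=O)c1cc(Oc2ccc(NC(=O)c3cc(-c4ccc(OC)cc4)ncn3)cc2)ccn1` differs from compound 1 by methoxy in place of chloro on an aromatic carbon. For the measured compounds named here, no measured step bears on this change, and all three values shown are limits, so the expected step is one of no change beyond the scatter, a number no higher from compound 1 to compound 4 (the limit leaves the size open). Compound 4 is therefore estimated at 100000 nM, between 30000 nM and 300000 nM, most probably again reported only as a limit.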

Compound 4, half-maximal inhibitory concentration: 29200 nM
The estimate for compound 4 lay 3.4-fold (0.53 log units) above the measured number, and the stated range ends above it.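

In this assay, among the compounds shown here, 4-chlorophenyl to 4-methoxyphenyl gives an at least 3.4-fold lower number from compound 1 to compound 4 (0.53 log units; beyond the scatter), the first readable step in the set. For the compounds shown here, this place, para to a large group, therefore responds to substitution, which the earlier compounds could not show. Compound 4 is the only compound here with a number instead of a limit: the limit of > 100000 nM in this assay, at which 3 of the 4 values shown sit.

From the compounds shown here alone, the full size of the step stays open, and so does whether methoxy would give a similar step on compound 3. How an amine or a carboxylic acid would read at the same place is also unknown.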